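A few compounds are considered here, and "the series" means these few. Any claim that something is new, unique, unknown or untested is made for them only; others in the source may bear on it.

In an ADME assay on the whole organism (Mus musculus, strain CD-1) for pharmacokinetics (on this read-out lower numbers stand for slow clearance and higher numbers for fast clearance), compound 1 `COc1cccc([C@H](c2cc3cc(C#N)ccc3nc2OC)[C@@](O)(CCN(C)C)c2cc(SC)nc(SC)c2)c1F` gives 44 mL/min/kg and compound 2 `COc1nc2ccc(C#N)cc2cc1[C@@H](c1cccc(C)c1F)[C@@](O)(CCN(C)C)c1cc(SC)nc(SC)c1` gives 22 mL/min/kg, the two values lying within the scatter of each other. Compound 3 `CCSc1cc([C@](O)(CCN(C)C)[C@@H](c2cc3cc(C#N)ccc3nc2OC)c2cccc(C)c2F)cc(SCC)n1` departs from compound 2 by one exchange: a group of 12 heavy atoms (9 carbon, 1 nitrogen, 2 sulfur; one six-membered aromatic ring with 1 hetero atom) in place of a group of 10 heavy atoms (7 carbon, 1 nitrogen, 2 sulfur; one six-membered aromatic ring with 1 hetero atom), on a saturated chain carbon bound to an oxygen on a saturated carbon and two saturated chain carbons. Within the data shown here, the only measured step, a 2.0-fold lower number from compound 1 to compound 2 (0.30 log units; within the scatter), is a different exchange, methyl in place of methoxy on an aromatic carbon, and it stays within the scatter. Among the measured compounds shown here, no measured step covers the present exchange, so no shift beyond the scatter is expected in this assay. The expected step is a 1.1-fold higher number from compound 2 to compound 3 (0.06 log units; within the scatter). For compound 3 the estimated clearance is 25 mL/min/kg, with an expected range of 12 mL/min/kg to 50 mL/min/kg.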

Compound 3, clearance: 9.4 mL/min/kg
The estimate for compound 3 lay 2.7-fold (0.42 log units) above the measured number, and the stated range ends above it.
By their numbers in this assay, from the lowest: compound 3; then compounds 2 and 1 (each within the scatter of the next).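

In this assay, among these compounds, the group of 12 heavy atoms in place of the group of 10 heavy atoms gives a 2.3-fold lower number from compound 2 to compound 3 (0.37 log units; beyond the scatter) and is the first step to pass beyond the scatter. Among the compounds shown here, the change on this saturated chain carbon therefore moves clearance, whereas the one earlier step, made at another place, stayed within the scatter. No measured evidence bears on the reason for this step.

From the compounds shown here alone, whether a longer chain on the same six-membered aromatic ring would extend the step remains open. So does whether an amine there would keep it.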